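A few compounds are considered here, and "the series" means these few. Any claim that something is new, unique, unknown or untested is made for them only; others in the source may bear on it.

Three compounds of this series carry a shared core and have been tested in a functional assay on HepG2 cells (Homo sapiens) for antiproliferative activity, read by CCK-8 assay, with a stated time of 72 h, tested at 2 uM; on this read-out lower numbers stand for a weaker effect and higher numbers for a stronger effect at the one concentration tested. Compound 1 `Nc1ccccc1NC(=O)c1ccc(CNc2nc(Cl)nc3c2ncn3Cc2ccccc2)cc1` gives 5.01%. Compound 3 `CC1CCN(c2nc(Cl)nc3c2ncn3Cc2ccc(C(=O)Nc3ccccc3N)cc2)CC1` gives 1.22%, and compound 2 `Nc1ccccc1NC(=O)/C=C/c1ccc(COCNc2nc(Nc3cccc(Cl)c3)c3ncn(C4CCCC4)c3n2)cc1` gives 9.67%. The number for compound 1 sits among these two, each separated from it by an amount within the usual scatter, so no ordering among the three can be claimed. Compound 4 `Nc1ccccc1NC(=O)c1ccc(CNc2nc(Cl)nc3c2ncn3C2CCCC2)cc1` differs from compound 1 in one place: cyclopentyl in place of benzyl on an aromatic nitrogen. Within the data shown here, no pair of measured compounds differs only by this change, so the effect of cyclopentyl in place of benzyl is not known here. The expected step of a number 1 percentage points higher from compound 1 to compound 4 (within the scatter) is none beyond the scatter. For compound 4 the estimate in this assay is 6%, within a range from 0% to 18%.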

Compound 4, a percentage reported as inhibition, at one concentration (the size of the read-out at that concentration, not a potency): 54.7%
Compound 4: middle estimate off by 48.7 percentage points, on the low side; measured number outside the range, above it.
By their numbers in this assay, from the lowest: compounds 3, 1 and 2 (each within the scatter of the next); then compound 4.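

In this assay, among these compounds, the group on this aromatic nitrogen proves to carry real weight: cyclopentyl in place of benzyl gives a number 49.7 percentage points higher from compound 1 to compound 4 (beyond the scatter) and thereby yields the first step beyond the scatter. The earlier compounds shown here included no pair differing in one place, so this sensitivity could not be seen from them. Nothing available explains the size of this step. From the compounds shown here alone, whether cyclohexyl or isopropyl on the same nitrogen would give a similar number remains open, as does whether the step would persist with an amine in place of the chlorine on the core.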